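A few compounds are considered here, and "the series" means these few. Any claim that something is new, unique, unknown or untested is made for them only; others in the source may bear on it.

Measured so far:
Compound 1 `O=C(O)Cc1ccc(-c2ccc(CN3CC(=O)N(c4ccccc4)C3=O)cc2)cc1`: 175 ug/mL
Compound 2 `O=C(O)Cc1ccccc1-c1cccc(NC(=O)OCc2ccccc2)c1`: 287 ug/mL

In a physicochemical assay for solubility, in phosphate buffer, measured as kinetic solubility, with a stated time of 1 h, at pH 7.4 (a higher number here means a more soluble compound, a lower number a less soluble compound), compound 1 gives the lower of the two numbers shown, yet its gap to compound 2 lies within the scatter, so the two cannot be told apart. Compound 3 `CC(C)N1C(=O)CN(Cc2ccc(-c3ccc(CC(=O)O)cc3)cc2)C1=O` has not been measured. It differs from compound 1 in one place: isopropyl in place of phenyl on an amide-type nitrogen in a ring. For the measured compounds named here, no measured pair shows a change of this kind, so nothing here tells its effect. The expected step is a 1.4-fold higher number from compound 1 to compound 3 (0.14 log units; within the scatter), which would stay within the scatter. Compound 3 is therefore estimated at 240 ug/mL, with a range from 110 ug/mL to 520 ug/mL.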

Compound 3, solubility: 190 ug/mL
The estimate for compound 3 lay 1.3-fold (0.10 log units) above the measured number; the range from low to high includes it.
By their numbers in this assay, from the lowest: compounds 1, 3 and 2 (each within the scatter of the next).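

In this assay, isopropyl in place of phenyl on an amide-type nitrogen in a ring gives a 1.1-fold higher number from compound 1 to compound 3 (0.04 log units; within the scatter) and so the two compounds cannot be told apart. At this position, then, an aromatic ring can give way to a group with no ring without a change that stands clear of the scatter. Nothing available accounts for this result.

Still open, as far as these compounds go, is whether an amine or a hydroxyl-bearing chain on this nitrogen would move the number beyond the scatter. Whether the same swap behaves alike on another core is also unknown.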